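Fluoro Substitution on a Shared Core in Prostate Cancer Cells

The source may report more compounds than this note shows. Statements on the series, on what has been measured and on what is new or still open speak of the compounds shown alone.

Compound 1 `O=C(Nc1ccc(Oc2ccnc3[nH]ccc23)cc1)c1nccc(-c2cccc(Cl)c2)n1` and compound 2 `O=C(Nc1ccc(Oc2ccnc3[nH]ccc23)cc1)c1cc(-c2ccccc2)ncn1` are built on different cores; the difference between the two cores is not broken down here. In a functional assay on PC-3 cells (Homo sapiens) for cytotoxicity, read by MTT assay, with a stated time of 72 h (on this read-out lower numbers stand for stronger inhibition and higher numbers for weaker inhibition), compound 1 gives 7800 nM, whereas compound 2 gives 240 nM in this assay. Compound 3 `O=C(Nc1ccc(Oc2ccnc3[nH]ccc23)c(F)c1)c1nccc(-c2cccc(Cl)c2)n1` differs from compound 1 by fluoro in place of hydrogen on an aromatic carbon, and in this assay compound 3 gives 1380 nM. The step is a 5.7-fold lower number from compound 1 to compound 3 (0.75 log units; beyond the scatter). Compound 4 `O=C(Nc1ccc(Oc2ccnc3[nH]ccc23)c(F)c1)c1cc(-c2ccccc2)ncn1` carries the same change on the core of compound 2, namely (fluoro in place of hydrogen on an aromatic carbon), at a place described in identical words. A somewhat smaller step is expected, a 2.5-fold lower number from compound 2 to compound 4 (0.40 log units; beyond the scatter), because a 5.7-fold lower number from compound 1 to compound 3 (0.75 log units; beyond the scatter) was seen once only and compound 2 already stands low. Compound 4 is therefore expected to give about 95 nM, estimated to lie between 30 nM and 300 nM.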

Compound 4, half-maximal inhibitory concentration: 40 nM
For compound 4 the middle estimate is 2.4-fold (0.38 log units) above the measured one; the range from low to high includes it.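

In this assay, fluoro in place of hydrogen on an aromatic carbon gives a 6.0-fold lower number from compound 2 to compound 4 (0.78 log units; beyond the scatter), so the change carries over to the core of compound 2 with much the same size as on the core of compound 1: the same change on two cores in this assay, a 5.7-fold lower number (0.75 log units; beyond the scatter) from compound 1 to compound 3 and a 6.0-fold lower number (0.78 log units; beyond the scatter) from compound 2 to compound 4, 1.1-fold (0.03 log units) apart, within the scatter of two such steps. Within these two pairs, then, the size of the step does not depend on which of the two cores carries it. This does not show why fluoro lowers the number, and two cores are too few to promise the same step on a third.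

The compounds shown leave open whether a methyl or methoxy group in place of the fluoro would lower the number as well. They also leave open whether an amine there would do so.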